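The source may report more compounds than this note shows. Statements on the series, on what has been measured and on what is new or still open speak of the compounds shown alone.

Measured in a functional assay on HeLa cells (Homo sapiens) for antiproliferative activity, read by MTT assay, with a stated time of 72 h; a higher number here means a weaker inhibitor, a lower number a stronger inhibitor:

- Compound 1 `COc1cc(-n2ncnc2-c2ccc(C)cc2)cc(OC)c1OC`: 250 nM
- Compound 2 `COc1cc(-n2ncnc2-c2ccc(Cl)cc2)cc(OC)c1OC`: > 10000 nM (a limit, not a number)
- Compound 3 `CCOc1cccc(-c2ncnn2-c2cc(OC)c(OC)c(OC)c2)c1`: > 10000 nM (a limit, not a number)

Compound 3 has no numerical value on these data, only the limit. Compound 4 `COc1cc(-n2ncnc2-c2cccc(F)c2)cc(OC)c1OC` differs from it by fluoro in place of ethoxy on an aromatic carbon, with fluoro in place of ethoxy on an aromatic carbon. Among the measured compounds shown here, one measured step bears on this change: an at least 40-fold higher number from compound 1 to compound 2 (1.60 log units; beyond the scatter). It shows that one exchange on an aromatic carbon can matter greatly, but it involves other groups and fixes no direction here. A lower number is expected in this assay, although compound 4 may also return only a limit. The expected change is an at least 3.3-fold lower number from compound 3 to compound 4 (0.52 log units; beyond the scatter). For compound 4 the estimated value is 3000 nM, with an expected range from 250 nM to 10000 nM.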

Compound 4, half-maximal inhibitory concentration: > 10000 nM
Compound 4: no number, only a limit (the forecaster's own chance of this, stated with the estimate: 45%); middle value at least 3.3-fold (0.52 log units) from the limit.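

In this assay compound 4 gives > 10000 nM as a limit and not a number. Fluoro in place of ethoxy thus yields no number at this position, and the steps from compound 3 and from compound 2 to compound 4 cannot be read: the limit of > 10000 nM in this assay, at which 3 of the 4 values shown sit. The exchange of 4-methylphenyl for 3-fluorophenyl gives an at least 40-fold higher number from compound 1 to compound 4 (1.60 log units; beyond the scatter) and leaves compound 1 as the only one of the four with a number. From the compounds shown here alone, whether an amine or a longer chain at this place would return a number stays open. So does how far compound 2, compound 3 and compound 4 lie past their limits.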